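A few compounds are considered here, and "the series" means these few. Any claim that something is new, unique, unknown or untested is made for them only; others in the source may bear on it.

Measured compounds:
Compound 1 `CC(=O)OC/C1=C/C[C@](C)(CCC=C(C)C)/C=C/[C@@H](OC(=O)C=C(C)C)[C@](C)(OC(C)=O)/C=C/C1=O`: 3480 nM
Compound 2 `CC(C)=CCC[C@]1(C)/C=C/[C@@H](OC(=O)C=C(C)C)[C@](C)(O)/C=C/C(=O)/C(CN(C)C)=C\C1`: 140 nM
Compound 3 `CC(C)=CCC[C@]1(C)/C=C/[C@@H](OC(=O)C=C(C)C)[C@](C)(O)/C=C/C(O)/C(C=O)=C\C1`: 240 nM

The three compounds were tested in a functional assay on HL-60 cells (Homo sapiens) for antiproliferative activity, read by MTT assay, with a stated time of 48 h; a lower number here means a stronger inhibitor, a higher number a weaker inhibitor. Compound 1 `CC(=O)OC/C1=C/C[C@](C)(CCC=C(C)C)/C=C/[C@@H](OC(=O)C=C(C)C)[C@](C)(OC(C)=O)/C=C/C1=O` gives 3480 nM in this assay. Compound 2 `CC(C)=CCC[C@]1(C)/C=C/[C@@H](OC(=O)C=C(C)C)[C@](C)(O)/C=C/C(=O)/C(CN(C)C)=C\C1` gives 140 nM, the lowest number of the three, while compound 3 `CC(C)=CCC[C@]1(C)/C=C/[C@@H](OC(=O)C=C(C)C)[C@](C)(O)/C=C/C(O)/C(C=O)=C\C1` gives 240 nM, which sits within the scatter of compound 2, so no order between compound 2 and compound 3 can be read from these numbers. Compound 1 stands well beyond the scatter from both.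

Compound 4 `CC(C)=CCC[C@]1(C)/C=C/[C@@H](OC(=O)C=C(C)C)[C@](C)(O)/C=C/C(=O)/C(C(=O)N(C(C)C)C(C)C)=C\C1` has not yet been measured in this assay. It differs from compound 2 in one place: diisopropylcarbamoyl in place of (dimethylamino)methyl on a double-bonded ring carbon. For the measured compounds named here, no pair of measured compounds shows this kind of exchange, so the size of the step cannot be taken from the numbers in hand. The account therefore rests on compound 2 alone, with its value of 140 nM as the anchor. Compound 4 is expected to show a moderate rise in this assay, a step of a 2.9-fold higher number from compound 2 to compound 4 (0.46 log units; beyond the scatter) that may well be beyond the scatter, but with a broad range because no comparable change has been observed. Compound 4 is estimated at 400 nM, within 100 nM to 1600 nM.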

Compound 4, half-maximal inhibitory concentration: 12700 nM
Estimate against measurement, compound 4: 32-fold (1.50 log units) below, outside the stated range (above it).
By their numbers in this assay, from the lowest: compounds 2 and 3 (each within the scatter of the next); then compound 1; then compound 4.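

Exchanging (dimethylamino)methyl for diisopropylcarbamoyl on the double-bonded ring carbon of the shared core gives a 91-fold higher number from compound 2 to compound 4 (1.96 log units; beyond the scatter) in this assay and so shows that this position is far from indifferent to what it carries. For the compounds shown here, the earlier compounds offered no pair differing in this place alone, which makes this step the first direct reading of how much a change here can cost. No measurement at hand accounts for the size of the step.

The exchange alters two things at once, the carbonyl now bound to the ring carbon and the isopropyl groups replacing the methyl groups on the nitrogen, and the compounds shown do not separate the two. Going by these compounds, a dimethylcarbamoyl group or a (diisopropylamino)methyl group on the same ring carbon would pull these apart, and it remains open whether a morpholinomethyl group or a carboxylic acid there would stay close to compound 2 at 140 nM or fall away as far as the amide does.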